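Relocating a Hydroxyl Within the Side Chain

A few compounds are considered here, and "the series" means these few. Any claim that something is new, unique, unknown or untested is made for them only; others in the source may bear on it.

Of the compounds shown here, three built on one shared core have been tested in a functional assay on A549 cells (Homo sapiens) for inhibition, read by sulforhodamine B assay, with a stated time of 48 h; a lower number here means a stronger inhibitor of growth, a higher number a weaker inhibitor of growth. Compound 1 `COC1=C(OC)[C@H](O)[C@H](C/C=C(\C)CC/C=C(\C)C[C@@H]2C[C@@H](C)C(=O)O2)[C@@H](C)C1=O` gives 14100 nM, compound 2 `COC1=C(OC)[C@H](OC(C)=O)[C@H](C/C=C(\C)CC/C=C(\C)C[C@H](O)C=C(C)C)[C@@H](C)C1=O` gives 20700 nM, and compound 3 `COC1=C(OC)[C@H](O)[C@H](C/C=C(\C)CC/C=C(\C)C/C=C/C(C)(C)O)[C@@H](C)C1=O` gives 23800 nM. Compound 3 thus holds the highest of the three numbers, yet its nearest neighbour, compound 2, sits close by, and the gap to compound 1 also stays within the usual scatter, so the three cannot be separated with confidence.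

Going by the values given here, the only single-point step among the measured compounds is a 1.7-fold higher number from compound 1 to compound 3 (0.23 log units; within the scatter), which trades a group holding one five-membered non-aromatic ring for an open chain without moving the number beyond the scatter.

Compound 4 `COC1=C(OC)[C@H](O)[C@H](C/C=C(\C)CC/C=C(\C)C[C@H](O)C=C(C)C)[C@@H](C)C1=O` has the same atoms as compound 3, joined differently: 1-hydroxy-3-methylbut-2-en-1-yl in place of 3-hydroxy-3-methylbut-1-en-1-yl on a saturated chain carbon bound to a double-bonded chain carbon. Among the compounds with values here, no measured pair isolates this rearrangement. Compound 2 carries the same 1-hydroxy-3-methylbut-2-en-1-yl chain as compound 4 and differs from it elsewhere; its number lies close to that of compound 3. Because a 1.7-fold higher number from compound 1 to compound 3 (0.23 log units; within the scatter) left the number within the scatter, compound 4 is expected to land near compound 3 as well, with a 1.3-fold lower number from compound 3 to compound 4 (0.10 log units; within the scatter) anticipated to stay within the scatter. The estimate for compound 4 in this assay is 19000 nM, within the range 9000 nM to 40000 nM.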

Compound 4, concentration for 50% growth inhibition: 9600 nM
The estimate for compound 4 lay 2.0-fold (0.30 log units) above the measured number; measured number inside the range.
By their numbers in this assay, from the lowest: compounds 4, 1, 2 and 3 (each within the scatter of the next, the first and the last beyond it).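

In this assay, going by these compounds alone, moving the hydroxyl within the side chain, with 1-hydroxy-3-methylbut-2-en-1-yl in place of 3-hydroxy-3-methylbut-1-en-1-yl on a saturated chain carbon bound to a double-bonded chain carbon, gives a 2.5-fold lower number from compound 3 to compound 4 (0.39 log units; beyond the scatter) and so provides the first evidence that this position responds to how the same atoms are joined, although the step is modest. With that side chain held fixed, hydrogen in place of acetyl on an oxygen on a saturated carbon gives a 2.2-fold lower number from compound 2 to compound 4 (0.33 log units; beyond the scatter) as a second modest step, which shows that the number also responds at this other place on the shared core. At the side-chain position, the step of a 1.5-fold lower number from compound 1 to compound 4 (0.17 log units; within the scatter) leaves the open chain of compound 4 and the group holding one five-membered non-aromatic ring in compound 1 inseparable in this assay.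

As far as these compounds go, it remains open whether the opposite configuration at the defined stereocentre of 1-hydroxy-3-methylbut-2-en-1-yl, or an amine in place of its hydroxyl, would keep the number of compound 4. The data shown offer no independent measurement that accounts for the size of these steps.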